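Alpha-carbon methyl removal in the sulfonamide amide series

The source may hold more compounds than are shown below. What is called first, only, known or untested is meant among the compounds shown, and "the series" means these compounds.

Compound 1 `Cc1ccc(CC(CNC(=O)C(C)(C)c2ccc(NS(C)(=O)=O)cc2)COC(=O)C(C)(C)C)cc1C` is the reference point. In a functional assay on CHO cells for antagonist activity at transient receptor potential cation channel subfamily V member 1 (Rattus norvegicus) (on this read-out higher numbers stand for weaker inhibition and lower numbers for stronger inhibition), compound 1 gives 104 nM, the second highest of the three numbers recorded. Its nearest neighbour is compound 3 `Cc1ccc(CC(CNC(=O)C(C)(C)c2ccc(NS(C)(=O)=O)c(F)c2)COC(=O)C(C)(C)C)cc1C`, which in this assay gives 65 nM; the step of a 1.6-fold lower number from compound 1 to compound 3 (0.20 log units; within the scatter) is within the scatter. Compound 2 `Cc1ccc(CC(CNC(=O)C2(c3ccc(NS(C)(=O)=O)cc3)CC2)COC(=O)C(C)(C)C)cc1C` gives 197 nM in this assay, and the two values for compound 1 and compound 2 also lie within the scatter of each other, so nothing separates these three.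

Compound 4 `Cc1ccc(CC(CNC(=O)C(C)c2ccc(NS(C)(=O)=O)cc2)COC(=O)C(C)(C)C)cc1C` is not yet measured. Compared with compound 1 it carries hydrogen in place of methyl on a saturated chain carbon bound to an aromatic carbon, a carbonyl carbon and a saturated chain carbon. Going by the values given here, no measured step touches this position: the one recorded step, the fluorination from compound 1 to compound 3, concerns the aromatic ring and was within the scatter, and compound 2 differs from compound 1 at the same saturated carbon but by a different change, with a value that sits within the scatter of compound 1.

Among the compounds with values here, with no direct precedent, the expectation for compound 4 in this assay is a step of a 2.4-fold higher number from compound 1 to compound 4 (0.38 log units; beyond the scatter), a modest weakening that may not exceed the scatter. The estimate for compound 4 is 250 nM, with a range from 80 nM to 800 nM.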

Compound 4, inhibition constant: 38 nM
Compound 4: the middle estimate sits 6.6-fold (0.82 log units) above what was measured, outside the stated range (below it).
By their numbers in this assay, from the lowest: compounds 4, 3, 1 and 2 (each within the scatter of the next, the first and the last beyond it).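

In this assay the hydrogen in place of methyl on a saturated chain carbon bound to an aromatic carbon, a carbonyl carbon and a saturated chain carbon gives the series its first step beyond the scatter (a 2.7-fold lower number from compound 1 to compound 4 (0.44 log units; beyond the scatter)), and that step runs towards stronger inhibition. The full pair of methyl groups on this carbon is therefore not required for inhibition in the compounds shown, whereas compound 2, changed at the same carbon in a different way, gives 197 nM and stays within the scatter of compound 1. The data shown offer no evidence that explains this step, which stands as an observation only.

Open, going by these compounds, is whether an ethyl group, a hydroxyl group or a fluorine atom on this carbon would keep the lower number seen with hydrogen, since only methyl and hydrogen can be compared here. Also open, on these data alone, is whether the fluoro on the aromatic carbon, whose step from compound 1 stays within the scatter (a 1.6-fold lower number from compound 1 to compound 3 (0.20 log units; within the scatter)), would change the number if combined with the hydrogen of compound 4.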